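Enlarging an Alkoxy Group: Compound 2 to Compound 4

The compounds below may be only part of what the source reports. "The series", "measured", "known", "first", "only" and "open" are said of these compounds alone.

Of the compounds shown here, three have been measured in a functional assay on HCT-116 cells (Homo sapiens) for cytotoxicity, read by MTT assay, with a stated time of 48 h, in the presence of a further agent that is not named here; on this read-out higher numbers stand for an effect only at larger amounts of compound and lower numbers for an effect already at smaller amounts. Compound 1 `Cc1c(Cc2ccccc2)c(NNC(=O)Nc2cc(Cl)nc(Cl)c2)nc2c1cnn2C` gives 13600 nM. Compound 2 `COc1ccc(-c2cc(NNC(=O)Nc3cc(Cl)nc(OC)c3)nc3c2cnn3C)cc1` gives 54200 nM, the second highest of the three numbers; compound 3 `COc1cc(NC(=O)NNc2cc(-c3ccc(F)cc3)c3cnn(C)c3n2)cc(Cl)n1` gives 75300 nM, and the step of a 1.4-fold higher number from compound 2 to compound 3 (0.14 log units; within the scatter) lies within the scatter, while compound 1 sits a larger distance away. Compound 4 `COc1ccc(-c2cc(NNC(=O)Nc3cc(Cl)nc(OC(C)C)c3)nc3c2cnn3C)cc1` is not yet measured and differs from compound 2 in one place: isopropyl in place of methyl on an oxygen on an aromatic ring. Among the measured compounds shown here, no measured step touches this oxygen-bound group; the only step available, a 1.4-fold higher number from compound 2 to compound 3 (0.14 log units; within the scatter), concerns a different ring and is itself within the scatter. Without a comparable step, no shift beyond the scatter is expected, so compound 4 is estimated at 50000 nM, within 18000 nM to 140000 nM, which means an expected step of a 1.1-fold lower number from compound 2 to compound 4 (0.04 log units; within the scatter).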

Compound 4, half-maximal effective concentration: 39800 nM
Beside the measured number, compound 4's estimate is 1.3-fold (0.10 log units) above it; the range from low to high includes it.
By their numbers in this assay, from the lowest: compound 1; then compounds 4, 2 and 3 (each within the scatter of the next).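

Among the compounds shown here, this is the first measured step at this oxygen-bound group: in this assay, isopropyl in place of methyl on an oxygen on an aromatic ring gives a 1.4-fold lower number from compound 2 to compound 4 (0.13 log units; within the scatter) and so stays within the scatter. The position therefore accepts the larger isopropyl group with no shift beyond the usual variation between repeats. Nothing available here offers an explanation for this result.

Still open, as far as these compounds go, is whether a longer chain, or one ending in an amine or a carboxylic acid, would move the number beyond the scatter at this oxygen. From the compounds shown here alone, it is also open whether isopropoxy would read the same alongside the fluoro-bearing ring of compound 3.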